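This account rests on a few compounds, and the source may have more. Where it says the series, first, only, none or still open, it means among the compounds named here.

Measured so far:
compound 1 `O=C(CCC(=O)OCCCCCCSc1ccc([N+](=O)[O-])c2nonc12)Nc1ccccc1F`, 9890 nM;
compound 2 `Cc1ccc(NC(=O)CCC(=O)OCCCCCCSc2ccc([N+](=O)[O-])c3nonc23)cc1`, 6800 nM.

Both were tested in an assay on isolated protein for inhibition of glutathione S-transferase P (Homo sapiens), with a stated time of 10 min; on this read-out higher numbers stand for weaker inhibition and lower numbers for stronger inhibition. Compound 1 stands at the highest of the two numbers; its nearest neighbour is compound 2, and the step of a 1.5-fold lower number from compound 1 to compound 2 (0.16 log units; within the scatter) is within the scatter, so the two compounds cannot be told apart on these numbers.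

Compound 3 `COc1ccc(NC(=O)CCC(=O)OCCCCCCSc2ccc([N+](=O)[O-])c3nonc23)cc1` has not yet been measured. It differs from compound 1 in one place: 4-methoxyphenyl in place of 2-fluorophenyl on an amide-type nitrogen. For the measured compounds named here, the only measured step that bears on this is the one from compound 1 to compound 2, where a different group on the same amide-type nitrogen gave a 1.5-fold lower number from compound 1 to compound 2 (0.16 log units; within the scatter), a change within the scatter. By that guide, no step beyond the scatter is expected in this assay for compound 3, and the estimate is a 1.3-fold lower number from compound 1 to compound 3 (0.12 log units; within the scatter). Compound 3 is therefore expected to come in at about 7500 nM, with a range from 3000 nM to 20000 nM.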

Compound 3, half-maximal inhibitory concentration: 420 nM
Estimate against measurement, compound 3: 18-fold (1.25 log units) above; measured number outside the range, below it.
By their numbers in this assay, from the lowest: compound 3; then compounds 2 and 1 (each within the scatter of the next).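

In this assay, the group on the amide-type nitrogen turns out to matter a great deal: 4-methoxyphenyl in place of 2-fluorophenyl gives a 24-fold lower number from compound 1 to compound 3 (1.37 log units; beyond the scatter). The change can be narrowed further, since methoxy in place of methyl on an aromatic carbon, with the rest of the molecule unchanged, gives a 16-fold lower number from compound 2 to compound 3 (1.21 log units; beyond the scatter). Not every replacement at this nitrogen moves the number, however: of the three groups shown, only 4-methoxyphenyl stands apart, while compounds 1 and 2 remain within the scatter of each other.

No measurement available here explains what the methoxy group does. The compounds shown also leave open whether a 4-ethoxyphenyl, 4-hydroxyphenyl or 4-aminophenyl group on the same nitrogen would keep the low number, or whether it belongs to methoxy alone.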